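Swapping a Phenylpropyl Amide for a Furan Amide

The source may report more compounds than this note shows. Statements on the series, on what has been measured and on what is new or still open speak of the compounds shown alone.

Compound 1 `O=C(CC1CCOCC1)Nc1ccc(N2CCN(c3ccc(OC[C@@H]4CO[C@@](Cn5cncn5)(c5ccc(Cl)cc5Cl)O4)cc3)CC2)cc1` gives > 50000 nM in a toxicity assay on L02 cells (Homo sapiens) for inhibition, read by MTT assay, with a stated time of 48 h (a higher number here means a weaker inhibitor, a lower number a stronger inhibitor), a limit of the assay.
Compound 2 `O=C(CCCc1ccccc1)Nc1ccc(N2CCN(c3ccc(OC[C@@H]4CO[C@@](Cn5cncn5)(c5ccc(Cl)cc5Cl)O4)cc3)CC2)cc1` gives > 50000 nM in this assay, again a limit.

Compound 2 thus stands at the limit, with no number of its own. Going by the values given here, the only measured step, a step that the two limits leave unreadable from compound 1 to compound 2, cannot be read because of the limit of > 50000 nM in this assay, at which 2 of the 2 values shown sit. Compound 3 `O=C(Nc1ccc(N2CCN(c3ccc(OC[C@@H]4CO[C@@](Cn5cncn5)(c5ccc(Cl)cc5Cl)O4)cc3)CC2)cc1)c1ccco1` differs from compound 2 by furan-2-yl in place of 3-phenylpropyl on a carbonyl carbon. Among the compounds with values here, no measured step resembles this change, and both known values sit at the limit. The expected step is a step that the limit leaves unreadable from compound 2 to compound 3, likely not beyond the scatter. Compound 3 is therefore estimated at 80000 nM, within 30000 nM to 300000 nM, most probably again reported as a limit.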

Compound 3, half-maximal inhibitory concentration: > 50000 nM
Compound 3 ended at the assay's limit (the forecaster's own chance of this, stated with the estimate: 85%); the middle value does not contradict the limit.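

No step between compound 1, compound 2 and compound 3 can be read, because each result is a limit and not a number: the limit of > 50000 nM in this assay, at which 3 of the 3 values shown sit.

On these data alone, whether these compounds differ at all in this assay, and at what concentration any of them would reach half-maximal inhibition, stays open.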